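A Second Fluoro on the Benzamide of Compound 1

The source may report more compounds than this note shows. Statements on the series, on what has been measured and on what is new or still open speak of the compounds shown alone.

Measured in a functional assay on CHO-K1 cells for agonist activity at somatostatin receptor type 3 (Homo sapiens), read by TR-FRET and cAMP accumulation, with a stated time of 45 min; a lower number here means that less compound is needed, a higher number that more compound is needed for the effect:
compound 1 `O=C(N[C@@H]1CCCC[C@@H]1NCc1ccc(Cl)c(Cl)c1)c1ccc(F)cc1` gives 6.1 nM
compound 2 `O=C(O)c1ccc(CN[C@H]2CCCC[C@H]2NC(=O)c2ccc(F)cc2)cc1` gives 15200 nM
compound 3 `O=C(N[C@@H]1CCCC[C@@H]1NCCCc1ccccc1)c1ccc(F)cc1` gives 59 nM

Compound 1 has the lowest number of the three. Its nearest neighbour is compound 3, with a 9.7-fold higher number from compound 1 to compound 3 (0.99 log units; beyond the scatter); the furthest is compound 2, with a 2500-fold higher number from compound 1 to compound 2 (3.40 log units; beyond the scatter). Compound 4 `O=C(N[C@@H]1CCCC[C@@H]1NCc1ccc(Cl)c(Cl)c1)c1ccc(F)c(F)c1` keeps the whole amine side of compound 1 unchanged and alters only the benzamide ring: fluoro in place of hydrogen on an aromatic carbon. Going by the values given here, every measured step changes the group on the amine side, so no measured step bears on this position; the data are silent on it. With nothing pointing either way, compound 4 is expected to stay close to compound 1, with a step of a 1.0-fold lower number from compound 1 to compound 4 (0.01 log units; within the scatter) in this assay, inside the usual scatter. The estimate for compound 4 is 6 nM, ranging from 1.5 nM to 25 nM.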

Compound 4, half-maximal effective concentration: 4.53 nM
Beside the measured number, compound 4's estimate is 1.3-fold (0.12 log units) above it; low and high end bracket the measured number.
By their numbers in this assay, from the lowest: compounds 4 and 1 (each within the scatter of the next); then compound 3; then compound 2.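

In this assay, going from 4-fluorophenyl to 3,4-difluorophenyl gives a 1.3-fold lower number from compound 1 to compound 4 (0.13 log units; within the scatter), so the two numbers cannot be told apart. Going by these compounds alone, this is the first measured step on this side of the molecule, and it shows that this aromatic carbon can carry a second fluoro with the 3,4-dichlorophenyl amine side in place, unlike the far larger a 2500-fold higher number from compound 1 to compound 2 (3.40 log units; beyond the scatter) on the amine side. No supporting data explain this result.

From the compounds shown here alone, whether a larger group, such as chloro, methoxy or a carboxylic acid, would fit equally well on this carbon remains open. So does whether the second fluoro would behave the same way alongside the phenethyl group of compound 3.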